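The source may report more compounds than this note shows. Statements on the series, on what has been measured and on what is new or still open speak of the compounds shown alone.

Measured so far: compound 1 `O=C1NC(=S)/C(=C/c2ccc(Cl)cc2)S1` with 41.4%; compound 2 `O=C1NC(=S)/C(=C/c2cccc(Cl)c2)S1` with 30.9%.

In a functional assay on NCI-H292 cells (Homo sapiens) for cytotoxicity, read by MTT assay, with a stated time of 72 h, tested at 10 ug/mL (on this read-out higher numbers stand for more inhibition of growth at the one concentration tested and lower numbers for less inhibition of growth), compound 1 gives 41.4% and compound 2 gives 30.9%. Of these two numbers compound 2 holds the lower, and its gap to compound 1 lies beyond the scatter. Compound 3 `O=C1NC(=S)/C(=C/c2ccc(Cl)c(Cl)c2)S1` is not yet measured; it differs from compound 2 by chloro in place of hydrogen on an aromatic carbon. Going by the values given here, no measured pair covers such a change, so only a modest rise in this assay is expected, guided by compound 1 at 41.4%. Compound 3 is estimated at 42%, ranging from 25% to 60%. For compound 3 this estimate means an expected step of a number 11.1 percentage points higher from compound 2 to compound 3 (beyond the scatter).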

Compound 3, percent growth inhibition at one concentration: 43.3%
The estimate for compound 3 lay 1.3 percentage points below the measured number, within the range that was stated.
By their numbers in this assay, from the lowest: compound 2; then compounds 1 and 3 (each within the scatter of the next).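

In this assay, chloro in place of hydrogen on the aromatic carbon ortho to a chloro group and para to a group of 8 heavy atoms gives a number 12.4 percentage points higher from compound 2 to compound 3 (beyond the scatter), so this position can take a chloro group with a gain in growth inhibition. The same kind of change made on compound 1 gives a number 1.9 percentage points higher from compound 1 to compound 3 (within the scatter), so the second chloro brings no clear gain there. The effect of adding chloro therefore depends on the compound it is added to, and nothing available explains this difference. From the compounds shown here alone, whether an amine or a methoxy group at this carbon would match chloro remains open.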